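Chloro in Place of Fluoro: Expecting Compound 4's Cytotoxicity

A few compounds are considered here, and "the series" means these few. Any claim that something is new, unique, unknown or untested is made for them only; others in the source may bear on it.

Of the compounds shown here, three built on a shared core have been tested in a functional assay on HepG2 cells (Homo sapiens) for cytotoxicity, read by MTT assay, with a stated time of 24 h; a lower number here means a stronger inhibitor, a higher number a weaker inhibitor. Compound 1 `O=C1/C(=C/c2ccccc2F)CN(S(=O)(=O)c2ccc(F)cc2)C/C1=C\c1ccccc1F` gives 8000 nM. Compound 2 `O=C1/C(=C/c2ccccc2F)CN(S(=O)(=O)c2ccc(Cl)cc2)C/C1=C\c1ccccc1F` differs from compound 1 by chloro in place of fluoro on an aromatic carbon, and in this assay compound 2 gives 10900 nM, which is a step of a 1.4-fold higher number from compound 1 to compound 2 (0.13 log units; within the scatter). Compound 3 `O=C1/C(=C/c2cccc(F)c2)CN(S(=O)(=O)c2ccc(F)cc2)C/C1=C\c1cccc(F)c1` gives 5000 nM in this assay. The difference between the core of compound 1 and the core of compound 3 is not broken down here; the two are made of the same atoms joined differently. Compound 3 shows the lowest of the three numbers, yet its gap to compound 1 is within the scatter, while its gap to compound 2 lies beyond it.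

Compound 4 `O=C1/C(=C/c2cccc(F)c2)CN(S(=O)(=O)c2ccc(Cl)cc2)C/C1=C\c1cccc(F)c1` has not yet been measured. It differs from compound 3 by chloro in place of fluoro on an aromatic carbon, and the place of the change reads the same as in the pair of compound 1 and compound 2, so it is the same change made on the other core. Because the earlier step was a 1.4-fold higher number from compound 1 to compound 2 (0.13 log units; within the scatter), a step of similar size is expected here, namely a 1.4-fold higher number from compound 3 to compound 4 (0.15 log units; within the scatter). Compound 4 is therefore expected to give about 7000 nM in this assay. The expected range for compound 4 runs from 3500 nM to 14000 nM, wide enough to hold the usual scatter and the possibility that the change behaves somewhat differently on this core.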

Compound 4, half-maximal inhibitory concentration: 13100 nM
Estimate against measurement, compound 4: 1.9-fold (0.27 log units) below; the measured number falls inside the stated range.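

In this assay, chloro in place of fluoro, the change from 4-fluorophenyl to 4-chlorophenyl on the sulfonyl group, also raised the number on the second core, giving a 2.6-fold higher number from compound 3 to compound 4 (0.42 log units; beyond the scatter). The change therefore moved the number in the same direction on both cores, and the two steps cannot be told apart in size: the same change on two cores in this assay, a 1.4-fold higher number (0.13 log units; within the scatter) from compound 1 to compound 2 and a 2.6-fold higher number (0.42 log units; beyond the scatter) from compound 3 to compound 4, 1.9-fold (0.28 log units) apart, within the scatter of two such steps. This supports carrying the direction of the change from one core to the other in these two pairs, but it does not establish a fixed step size, since only the newer step stands clear of the scatter, and it neither shows nor rules out a real dependence of the step on the core, and it offers no explanation for the result.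

The compounds shown leave open whether other groups in the same place on the aromatic ring, such as a methoxy group, a nitrile or an amine, would shift the number in this assay in the same direction as chloro. They also leave open whether the chloro step would hold on a core that carries chloro or methyl in place of its own fluoro groups, or in any other cell line.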